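Adding a Second Methyl to a Fused Core

This account rests on a few compounds, and the source may have more. Where it says the series, first, only, none or still open, it means among the compounds named here.

Three compounds have been measured in an assay on HEK293-TREx cells for antagonist activity at transient receptor potential cation channel subfamily A member 1 (Homo sapiens), read by fluorescence and calcium flux, with a stated time of 72 h; a lower number here means a stronger inhibitor, a higher number a weaker inhibitor:

Compound 1, `Fc1ccc(Oc2ncnc3[nH]ccc23)c(F)c1`: 710 nM
Compound 2, `Fc1cccc(Oc2ncnc3[nH]ccc23)c1F`: 2700 nM
Compound 3, `Cc1cc2c(Oc3ccc(F)cc3F)ncnc2[nH]1`: 1200 nM

Compound 3 holds the second highest number of the three. Its nearest neighbour is compound 1, whose number is lower by an amount within the scatter, while compound 2 gives a higher number than compound 3 by an amount beyond the scatter. Compound 4, `Cc1[nH]c2ncnc(Oc3ccc(F)cc3F)c2c1C`, is not yet measured. It differs from compound 3 by one change: methyl in place of hydrogen on an aromatic carbon. This puts a second methyl group on the five-membered ring of the shared core.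

Among the measured compounds shown here, one measured step bears on this change. Going a 1.7-fold higher number from compound 1 to compound 3 (0.23 log units; within the scatter) was also a methyl in place of hydrogen on an aromatic carbon of that ring, and the number barely moved. The same kind of change is therefore expected to leave this assay roughly where it is, with at most a small drift to a higher number. Compound 4 is estimated at 1500 nM, within 600 nM to 4000 nM, a step of a 1.3-fold higher number from compound 3 to compound 4 (0.10 log units; within the scatter) expected from compound 3.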

Compound 4, half-maximal inhibitory concentration: 2000 nM
For compound 4 the middle estimate is 1.3-fold (0.12 log units) below the measured one; measured number inside the range.
By their numbers in this assay, from the lowest: compounds 1, 3, 4 and 2 (each within the scatter of the next, the first and the last beyond it).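

In this assay, methyl in place of hydrogen on this second aromatic carbon gives a 1.7-fold higher number from compound 3 to compound 4 (0.22 log units; within the scatter), so a methyl next to the ring atom that already bears a methyl group leaves a step within the scatter. The five-membered aromatic ring has now taken a methyl at two of its carbons, and the earlier step, a 1.7-fold higher number from compound 1 to compound 3 (0.23 log units; within the scatter), is also within the scatter, so neither methyl step can be told apart from repeat measurement. Nothing shown gives a cause for this result.

As far as these compounds go, whether this carbon would accept anything other than methyl, such as an ethyl group, an amine or a carboxylic acid, remains open. So does whether the fluorine arrangement of compound 2 would give a similar number on the core of compound 4.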